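Porcupine inhibitors: methoxy to chloro on the benzothiazole amide

This account rests on a few compounds, and the source may have more. Where it says the series, first, only, none or still open, it means among the compounds named here.

Measured so far:
compound 1, `COc1ccc2nc(NC(=O)CNC(=O)c3nn(-c4ccccc4)c(=O)c4ccccc34)sc2c1`: 210 nM
compound 2, `O=C(CNC(=O)c1nn(-c2ccccc2)c(=O)c2ccccc12)Nc1nc2ccc(Cl)cc2s1`: 30 nM
compound 3, `COc1ccc(-n2c(SCC(=O)Nc3nc4ccc(OC)cc4s3)nc3c(c2=O)SCC3)cc1`: 120 nM

All three compounds were tested in an assay on L cells for inhibition of Protein-serine O-palmitoleoyltransferase porcupine (Mus musculus), read by reporter gene assay, with a stated time of 24 h; on this read-out higher numbers stand for an effect only at larger amounts of compound and lower numbers for an effect already at smaller amounts. Compound 1 carries the 6-methoxy-1,3-benzothiazol-2-yl amide on the first core and gives 210 nM. Among the measured compounds shown here, compound 2 is its single-point analogue, (chloro in place of methoxy on an aromatic carbon), and in this assay compound 2 gives 30 nM; the step of a 7.0-fold lower number from compound 1 to compound 2 (0.85 log units; beyond the scatter) is the only measured pair on which the change can be judged.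

Compound 3 keeps the same 6-methoxy-1,3-benzothiazol-2-yl amide but on a different core; the difference between the two cores is not broken down here. In this assay compound 3 gives 120 nM, which lies within the scatter of compound 1 and beyond it relative to compound 2.

Compound 4, `COc1ccc(-n2c(SCC(=O)Nc3nc4ccc(Cl)cc4s3)nc3c(c2=O)SCC3)cc1`, is not yet measured. It relates to compound 3 as compound 2 relates to compound 1: chloro in place of methoxy on an aromatic carbon. The two place descriptions agree word for word, so this is the same change, now made on the second core. For the measured compounds named here, the expectation for compound 4 rests on compound 1 and compound 2 alone, because a 7.0-fold lower number from compound 1 to compound 2 (0.85 log units; beyond the scatter) is the single precedent, and transfer across cores is not guaranteed. The step is expected to be somewhat smaller, around a 4.8-fold lower number from compound 3 to compound 4 (0.68 log units; beyond the scatter), allowing for the core difference. Compound 4 is therefore estimated at 25 nM, with a range of 8 nM to 80 nM expected.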

Compound 4, half-maximal effective concentration: 35 nM
Estimate against measurement, compound 4: 1.4-fold (0.15 log units) below; low and high end bracket the measured number.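

In this assay, replacing 6-methoxy-1,3-benzothiazol-2-yl with 6-chloro-1,3-benzothiazol-2-yl on the core of compound 3 gives a 3.4-fold lower number from compound 3 to compound 4 (0.54 log units; beyond the scatter), so the change carries over to this second core in the same direction and with a step beyond the scatter. The size of the step also holds up, as the two steps cannot be told apart: the same change on two cores in this assay, a 7.0-fold lower number (0.85 log units; beyond the scatter) from compound 1 to compound 2 and a 3.4-fold lower number (0.54 log units; beyond the scatter) from compound 3 to compound 4, 2.0-fold (0.31 log units) apart, within the scatter of two such steps. Among the compounds shown here, this shows that the change transfers between these two cores, but with only one matched pair per core it does not show that the step is truly smaller on the second core, nor that the change would carry to any further core.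

The compounds shown leave open how other groups would read at this place on the benzothiazole, for example fluoro, trifluoromethyl, nitrile or an amine, and hence whether chloro is a particularly good replacement or merely one of several that lower the number. Also open, on these data alone, is whether the step survives other changes to the molecule, such as a longer chain between the core and the amide, and whether it appears in any read-out other than this reporter gene measurement.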